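Taking One Methoxy Group off Compound 2

This account rests on a few compounds, and the source may have more. Where it says the series, first, only, none or still open, it means among the compounds named here.

Of the compounds shown here, two with a shared core have been measured in a functional assay on SK-OV-3 cells (Homo sapiens) for antiproliferative activity, read by sulforhodamine B assay, with a stated time of 48 h; a higher number here means a weaker inhibitor, a lower number a stronger inhibitor. Compound 1 (`CCc1cccc(NS(=O)(=O)c2ccc(N3CCNC3=O)cc2)c1`) gives 230 nM, and compound 2 (`COc1cc(NS(=O)(=O)c2ccc(N3CCNC3=O)cc2)cc(OC)c1OC`) gives 22 nM. Compound 2 therefore holds the lower of the two numbers, and its gap to compound 1 lies beyond the usual scatter. Compound 3 (`COc1cc(NS(=O)(=O)c2ccc(N3CCNC3=O)cc2)cc(OC)c1`) has hydrogen in place of methoxy on an aromatic carbon, ortho to two methoxy groups and para to a large group: hydrogen in place of methoxy on an aromatic carbon. Among the compounds with values here, no measured pair shows this change alone, so any forecast is indirect. Compound 1, which carries no methoxy group, stands at 230 nM, and this points towards a weaker inhibitor. The expected step, towards a higher number and beyond the scatter, is estimated as a 5.5-fold higher number from compound 2 to compound 3 (0.74 log units; beyond the scatter). In this assay compound 3 is expected at 120 nM, with an estimated range from 35 nM to 450 nM.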

Compound 3, half-maximal inhibitory concentration: 170 nM
Compound 3: the middle estimate sits 1.4-fold (0.15 log units) below what was measured; the range from low to high includes it.
By their numbers in this assay, from the lowest: compound 2; then compounds 3 and 1 (each within the scatter of the next).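

In this assay, within the data shown here, replacing with hydrogen the methoxy group that lies ortho to two methoxy groups and para to a large group gives a 7.7-fold higher number from compound 2 to compound 3 (0.89 log units; beyond the scatter) and isolates this position for the first time, since compounds 1 and 2 differ in more than one place. The step shows that this one methoxy group matters on its own: compound 3 keeps the other two methoxy groups, yet does not match compound 2 at 22 nM in that assay. The data offer no measured explanation for this loss.

On these data alone, it remains open whether a hydroxyl, a fluorine atom, an amine or an ethoxy group at this position would keep the number of compound 2. The compounds shown also leave open how much each of the other two methoxy groups contributes when taken away alone.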